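Swapping the Carbamate Arm for a Bromopyridyl Ether

The source may hold more compounds than are shown below. What is called first, only, known or untested is meant among the compounds shown, and "the series" means these compounds.

Two compounds have been measured in an assay on frontal cortex for displacement of a labelled ligand from corticotropin-releasing factor receptor 1 (Rattus norvegicus), with a stated time of 2 h; a higher number here means a weaker inhibitor, a lower number a stronger inhibitor:

Compound 1, `COc1nc(C)c(Nc2nc(Cl)cn([C@H](COC(C)=O)C3CC3)c2=O)cc1C`, gives 5.3 nM.
Compound 2, `COc1nc(C)c(Nc2nc(Cl)cn([C@H](COC(=O)Nc3cc(Cl)cc(Cl)c3)C3CC3)c2=O)cc1C`, gives 1.7 nM.

Compound 2 holds the lowest of the two numbers, and its nearest neighbour is compound 1, from which it is separated by a 3.1-fold lower number from compound 1 to compound 2 (0.49 log units; beyond the scatter). That single step changed only the group on a carbonyl carbon; the acetate arm of compound 1 became a carbamate bearing a (3,5-dichlorophenyl)amino group in compound 2.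

Compound 3, `COc1nc(C)c(Nc2nc(Cl)cn([C@H](COc3cc(Br)ccn3)C3CC3)c2=O)cc1C`, goes further. 4-bromopyridin-2-yl in place of (3,5-dichlorophenyl)carbamoyl on an oxygen on a saturated carbon The carbonyl and its attached nitrogen disappear, and a ring is joined directly to the oxygen. Within the data shown here, no measured step covers such a change, so the only evidence is indirect: both compound 1 and compound 2 bind tightly despite differing arms on the same oxygen, which suggests the shared core carries most of the binding while the arm tunes it. The step from compound 2 to compound 3 is therefore expected to be small, a 2.1-fold higher number from compound 2 to compound 3 (0.31 log units; beyond the scatter), most likely a slight weakening, since the dichlorophenyl carbamate that helped compound 2 is lost. Compound 3 is estimated at 3.5 nM, within a range of 0.9 nM to 14 nM.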

Compound 3, half-maximal inhibitory concentration: 1.5 nM
Compound 3: middle estimate off by 2.3-fold (0.37 log units), on the high side; the range from low to high includes it.
By their numbers in this assay, from the lowest: compounds 3 and 2 (each within the scatter of the next); then compound 1.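

On an oxygen on a saturated carbon, the arm can lose its carbonyl and the amide hydrogen without any reading of a difference in this assay: the swap to the 4-bromopyridin-2-yl group, which has fewer heavy atoms and no hydrogen-bond donor, gives a 1.1-fold lower number from compound 2 to compound 3 (0.05 log units; within the scatter). The lower number relative to the acetate therefore does not depend on the carbamate link or the dichlorophenyl ring, since replacing acetyl with the bromopyridyl group also gives a 3.5-fold lower number from compound 1 to compound 3 (0.55 log units; beyond the scatter), a step that matches the earlier gain seen with compound 2. There is no measurement here that explains why two such different arms give readings this close.

From the compounds shown here alone, what remains open is which part of the new arm matters, since the bromine and the ring nitrogen arrive together and compound 3 alone cannot separate them. A plain pyridin-2-yl or an unsubstituted phenyl on the same oxygen would pull those two contributions apart, and a chlorine or a methyl in place of the bromine would show how much that one atom matters.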